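The source may report more compounds than this note shows. Statements on the series, on what has been measured and on what is new or still open speak of the compounds shown alone.

Working notes on the series. Compound 1 `CC1(c2ccc(-c3ccc(/C(N)=N\O)cc3)cc2)CC(S(=O)(=O)c2ccc(F)cc2)=C(c2ccc(/C(N)=N\O)cc2)O1` and compound 2 `CC1(c2ccc(-c3cccc(/C(N)=N\O)c3)cc2)CC(S(=O)(=O)c2ccc(F)cc2)=C(c2ccc(/C(N)=N\O)cc2)O1` share one core; in an ADME assay on HepG2 cells (Homo sapiens) for cytotoxicity, read by MTT assay, with a stated time of 72 h (on this read-out higher numbers stand for lower toxicity in this test and lower numbers for higher toxicity in this test), compound 1 gives 15300 nM and compound 2 gives 19000 nM, the two lying within the scatter of each other a 1.2-fold higher number from compound 1 to compound 2 (0.09 log units; within the scatter). Compound 3 `Cc1ccc(-c2ccc(C3(C)CC(S(=O)(=O)c4ccc(F)cc4)=C(c4ccc(/C(N)=N\O)cc4)O3)cc2)cc1` differs from compound 2 by a group of 7 heavy atoms (7 carbon; one six-membered aromatic ring of carbon only) in place of a group of 10 heavy atoms (7 carbon, 2 nitrogen, 1 oxygen; one six-membered aromatic ring of carbon only), on an aromatic carbon. Within the data shown here, no measured step bears on this kind of exchange, so nothing beyond the scatter is expected in this assay for a 1.3-fold lower number from compound 2 to compound 3 (0.10 log units; within the scatter), though with a wide range. Compound 3 is therefore estimated at 15000 nM, between 5000 nM and 40000 nM.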

Compound 3, half-maximal cytotoxic concentration: 13700 nM
The estimate for compound 3 lay 1.1-fold (0.04 log units) above the measured number; low and high end bracket the measured number.
By their numbers in this assay, from the lowest: compounds 3, 1 and 2 (each within the scatter of the next).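

In this assay, 4-methylphenyl at this aromatic carbon, para to a large group, gives a 1.4-fold lower number from compound 2 to compound 3 (0.14 log units; within the scatter) and also a 1.1-fold lower number from compound 1 to compound 3 (0.05 log units; within the scatter) when read against the other measured isomer. Unlike the step between the two earlier compounds, these exchanges take the nitrogen and oxygen atoms out of this group, and the number still stays within the scatter. No measurement at hand accounts for this result.

On these data alone, whether an amine or a carboxylic acid in the same place would also stay within the scatter remains open. So does any exchange at the other ring of the shared core that carries the same nitrogen and oxygen group.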